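A few compounds are considered here, and "the series" means these few. Any claim that something is new, unique, unknown or untested is made for them only; others in the source may bear on it.

Of the compounds shown here, two have been measured in an assay on isolated protein for inhibition of sodium channel protein type 4 subunit alpha (Homo sapiens) (a lower number here means that less compound is needed, a higher number that more compound is needed for the effect), so far. Compound 1, with the structure `N[C@H](COc1ccc(Cl)cc1)c1ccccc1`, gives 3020 nM. Among the measured compounds shown here, compound 2, with the structure `Cc1cccc(C)c1SC[C@H](C)CN`, gives 2690 nM, a number that lies within the scatter of the one for compound 1, so the two cannot be told apart on these figures.

The next compound, compound 3, has the structure `Cc1cccc(C)c1SC[C@@H](C)CN`. Compared with compound 2, (the two compounds have the same atoms and bonds and differ only in configuration as drawn: 1 of 1 stereo elements differ; a stereocentre at a saturated chain carbon is drawn R in compound 2 and S in compound 3). For the measured compounds named here, with only one pair of compounds measured, nothing here tells how the mirror-image arrangement at that chain carbon bears on binding, and a change in either direction, or none beyond the scatter, remains possible. The estimate for compound 3 in this assay is therefore a cautious one: 4000 nM, with a range from 1500 nM to 15000 nM. This estimate corresponds to a step of a 1.5-fold higher number from compound 2 to compound 3 (0.17 log units; within the scatter).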

Compound 3, half-maximal effective concentration: 1910 nM
Estimate against measurement, compound 3: 2.1-fold (0.32 log units) above; the range from low to high includes it.
By their numbers in this assay, from the lowest: compounds 3, 2 and 1 (each within the scatter of the next).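

In this assay, moving the chain carbon from R to S gives a 1.4-fold lower number from compound 2 to compound 3 (0.15 log units; within the scatter). Among the compounds shown here, this is the first direct look at this stereocentre, and on these figures the two mirror-image forms cannot be told apart, so the arrangement at this carbon shows no clear bearing on the number in this pair. The comparison isolates that single feature: the fact that compounds 2 and 3 differ only in the configuration as drawn.

The compounds shown leave open whether the same holds in other settings, for instance with a longer chain between the sulfur and the amine, or with an amide in place of the primary amine. They also do not tell whether the stereocentre of compound 1 behaves in the same way, since its mirror-image form is not among them.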